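Propyl to tert-butyl on the shared core of compound 3

The compounds below may be only part of what the source reports. "The series", "measured", "known", "first", "only" and "open" are said of these compounds alone.

The series is read in a functional assay for inhibition, with Homo sapiens as the target; on this read-out higher numbers stand for weaker inhibition and lower numbers for stronger inhibition. Within the data shown here, compound 3 `CCCc1nc(C)c2cnnc(O)n12` gives 56800 nM in this assay, the only number among the three measured compounds. Compound 1 `CCCc1nc(C)c2c(C(C)C)nnc(O)n12` gives only a limit, > 48000 nM. Compound 2 `Cc1nc(Cc2ccccc2)n2c(O)nncc12` likewise gives only a limit, > 48000 nM. Because of the limit of > 48000 nM in this assay, at which 2 of the 3 values shown sit, the two measured steps, a step that the limit leaves unreadable from compound 1 to compound 3 and a step that the limit leaves unreadable from compound 2 to compound 3, cannot be sized; they concern hydrogen in place of isopropyl on an aromatic carbon and ethyl in place of phenyl on a saturated chain carbon bound to an aromatic carbon, and neither touches the group changed next.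

Compound 4 `Cc1nc(C(C)(C)C)n2c(O)nncc12` differs from compound 3 by tert-butyl in place of propyl on an aromatic carbon. Among the measured compounds shown here, no measured step bears on this change, and the two steps that exist are unreadable, so no direction can be drawn from them. The expected step of a 1.1-fold higher number from compound 3 to compound 4 (0.02 log units; within the scatter) in this assay is therefore none beyond the scatter, in either direction. Compound 4 is estimated at 60000 nM, between 25000 nM and 150000 nM, with a fair chance that this assay again reports only a limit.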

Compound 4, half-maximal inhibitory concentration: 31000 nM
Compound 4: middle estimate off by 1.9-fold (0.29 log units), on the high side; the measured number falls inside the stated range.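

In this assay, tert-butyl in place of propyl on an aromatic carbon gives a 1.8-fold lower number from compound 3 to compound 4 (0.26 log units; within the scatter), so at this position between two ring nitrogen atoms the exchange shows no effect beyond the scatter. Compound 4 also returns a number and not a limit, which makes this the only step shown that can be sized. The other two steps cannot be read, because of the limit: the limit of > 48000 nM in this assay, at which 2 of the 4 values shown sit.

On these data alone, whether an amine, a carboxylic acid or a longer chain at this position would move the number beyond the scatter stays open. With propyl and tert-butyl as the only pair compared here, the compounds shown give no trend for this position, and they do not show whether the result would hold with isopropyl also present on the shared core.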